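The compounds below may be only part of what the source reports. "The series", "measured", "known", "first", "only" and "open" are said of these compounds alone.

Measured so far in an in vitro functional assay on cells for agonist activity at Bombesin receptor subtype-3 (Mus musculus), read by luminescence and calcium flux; on this read-out higher numbers stand for an effect only at larger amounts of compound and lower numbers for an effect already at smaller amounts:
compound 1 `COc1ccc(Cc2cnc(CCc3ccc(-c4ccccc4C(=O)O)cc3)[nH]2)cc1` — 513 nM
compound 2 `CCC(C)(C)Cc1c[nH]c(CCc2ccc(-c3ccccc3C(=O)O)cc2)n1` — 9.6 nM

Compound 1 gives the highest of the two numbers; compound 2 sits well below it, the gap lying beyond the scatter. Among the measured compounds shown here, no single-point step connects the two structures, so the comparison rests on their values alone.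

Compound 3 `O=C(O)c1ccccc1-c1ccc(CCc2ncc(Cc3ccc(F)cc3)[nH]2)cc1` is drawn from compound 1 by one change: fluoro in place of methoxy on an aromatic carbon. The group sits on an aromatic carbon of a six-membered aromatic ring of carbon only, para to a large group.

With no measured step of this kind in the set, only a small move is expected, if any, and it may stay within the scatter. For compound 3 the expected step is a 1.4-fold lower number from compound 1 to compound 3 (0.13 log units; within the scatter), toward a slightly lower number. Compound 3 is estimated at 380 nM, in the range 120 nM to 1200 nM.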

Compound 3, half-maximal effective concentration: 50 nM
The estimate for compound 3 lay 7.6-fold (0.88 log units) above the measured number, outside the stated range (below it).
By their numbers in this assay, from the lowest: compound 2; then compound 3; then compound 1.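

In this assay the substituent on the aromatic ring of the benzyl group proves far from silent: fluoro in place of methoxy gives a 10-fold lower number from compound 1 to compound 3 (1.01 log units; beyond the scatter). Among the compounds shown here, since 4-fluorobenzyl for 4-methoxybenzyl is the only difference within this pair, the whole step belongs to this one position. Nothing at hand bears on what lies behind the step.

From the compounds shown here alone, whether the step reflects the loss of methoxy or the arrival of fluoro remains open. Chloro, hydroxyl or plain hydrogen at this same place would help separate the two readings.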